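Swapping the Aryl Group on an Aromatic Nitrogen

The compounds below may be only part of what the source reports. "The series", "measured", "known", "first", "only" and "open" are said of these compounds alone.

Compound 1 `CCOc1ccc(-n2nncc2CN2C(=O)C3(C(C#N)=C(N)Oc4c3c3nc5ccccc5nc3c3ccccc43)c3ccccc32)cc1` and compound 2 `Cc1ccc(Cl)cc1-n1nncc1CN1C(=O)C2(C(C#N)=C(N)Oc3c2c2nc4ccccc4nc2c2ccccc32)c2ccccc21` share one core and differ only in the aryl group that sits on an aromatic nitrogen. In a functional assay on A549 cells (Homo sapiens) for antiproliferative activity, read by MTT assay, with a stated time of 48 h (on this read-out lower numbers stand for stronger inhibition and higher numbers for weaker inhibition), compound 1 gives 25200 nM. For compound 2 the measurement in this assay reached only a limit of the assay, > 50000 nM, so no exact number is known for it. The step of an at least 1.9-fold higher number from compound 1 to compound 2 (0.29 log units; that floor lies within the scatter) therefore cannot be sized exactly; compound 2 stands at the limit of > 50000 nM in this assay, at which 1 of the 2 values shown sits.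

Compound 3 `N#CC1=C(N)Oc2c(c3nc4ccccc4nc3c3ccccc23)C12C(=O)N(Cc1cnnn1-c1ccc(F)c(Cl)c1)c1ccccc12` has not been measured yet. It differs from compound 2 in one place: 3-chloro-4-fluorophenyl in place of 5-chloro-2-methylphenyl on an aromatic nitrogen. Within the data shown here, only one measured step bears on this kind of exchange, an at least 1.9-fold higher number from compound 1 to compound 2 (0.29 log units; that floor lies within the scatter), and that step stayed within the scatter. Among the measured compounds shown here, with compound 2 known only as a limit, the numbers give no direction for the step to compound 3, and no change beyond the scatter is expected in this assay. Compound 3 is thus expected to stay close to where compound 2 stands, with an expected step of an at least 1.1-fold lower number from compound 2 to compound 3 (0.04 log units; that floor lies within the scatter). The estimate for compound 3 is 45000 nM, in an expected range from 18000 nM to 100000 nM.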

Compound 3, half-maximal inhibitory concentration: > 50000 nM
Compound 3: only a limit was reported (the forecaster's own chance of this, stated with the estimate: 45%); at least 1.1-fold (0.04 log units) between middle value and limit.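

In this assay, a second aryl group on this aromatic nitrogen, 3-chloro-4-fluorophenyl, gives no exact number either, so compound 2 and compound 3 both end at a limit of the assay: the limit of > 50000 nM in this assay, at which 2 of the 3 values shown sit.

Compared with the one exact value in the set, the record reads an at least 1.9-fold higher number from compound 1 to compound 3 (0.29 log units; that floor lies within the scatter), so this second exchange also cannot be shown to go beyond the scatter. Among these compounds, the step between compound 2 and compound 3 cannot be read because both are limits, which means 5-chloro-2-methylphenyl and 3-chloro-4-fluorophenyl cannot be ranked against each other, and compound 1 remains the only compound here with a measured number.

It remains open whether any aryl group at this position can move the reading clearly away from that of compound 1, since none of the steps shown establishes a change beyond the scatter. As far as these compounds go, how a phenyl ring carrying an amine or a carboxylic acid, or a plain phenyl ring, would behave here also remains unknown.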